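Aryl Ether Swap on a Bicyclic Amine Nicotinic Ligand

The compounds below may be only part of what the source reports. "The series", "measured", "known", "first", "only" and "open" are said of these compounds alone.

Measured compounds:
- compound 1, `Clc1ccc(Oc2cncc(C3=CC4CNCC(C3)C4)c2)cc1`: 1.9 nM
- compound 2, `C1=C(c2ccc(-c3ccccc3)nc2)CC2CNCC1C2`: 105 nM

In an in vitro assay on SH-EP1 cells for displacement of a labelled ligand from Neuronal acetylcholine receptor; alpha4/beta2 (Homo sapiens) (on this read-out higher numbers stand for weaker inhibition and lower numbers for stronger inhibition), compound 1 gives 1.9 nM, the lowest of the two numbers recorded. For the measured compounds named here, compound 2, which carries a phenyl group directly on the pyridine ring instead of an aryl ether, gives 105 nM in this assay, a much higher number that lies beyond the scatter; no single-change step connects these two compounds, so only their two values speak.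

Compound 3 is `COc1cccc(Oc2cncc(C3=CC4CNCC(C3)C4)c2)c1`. It differs from compound 1 in one place: 3-methoxyphenyl in place of 4-chlorophenyl on an oxygen on an aromatic ring. The shared core and the aryl ether linkage are kept, so the change is confined to the distal aromatic ring. Going by the values given here, with no measured step to guide the size of such an exchange, the account expects only a small shift in this assay, toward a slightly higher number, and not clearly beyond the scatter. The step from compound 1 to compound 3 is estimated at a 1.8-fold higher number from compound 1 to compound 3 (0.27 log units; within the scatter). Compound 3 is therefore expected to give 3.5 nM in this assay, within a range of 1 nM to 12 nM.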

Compound 3, inhibition constant: 0.9 nM
Compound 3: the middle estimate sits 3.9-fold (0.59 log units) above what was measured; the measured number lies below the stated range.
By their numbers in this assay, from the lowest: compound 3; then compound 1; then compound 2.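

In this assay, exchanging 4-chlorophenyl for 3-methoxyphenyl on an oxygen on an aromatic ring gives a 2.1-fold lower number from compound 1 to compound 3 (0.32 log units; beyond the scatter) and this modest step lies beyond the scatter. For the compounds shown here, it is the first single-change step available at this position, so it shows what compound 1 and compound 2 alone could not: the distal aromatic ring can be replaced here with the number staying low and even moving lower, although the entering group has 8 heavy atoms and 1 hydrogen-bond acceptor, against 7 heavy atoms and 0 hydrogen-bond acceptors in the group that leaves. No measurement presented here bears on why the number moves in this direction.

This step alters both the kind of substituent and where it sits on the distal ring, so the compounds shown do not tell which of the two accounts for the shift. They also leave open how the number would respond to an amine, a carboxylic acid or a longer ether chain on that ring.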